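This account rests on a few compounds, and the source may have more. Where it says the series, first, only, none or still open, it means among the compounds named here.

Measured so far in an ADME assay on Vero cells (Chlorocebus sabaeus) for cytotoxicity, read by resazurin assay, with a stated time of 3 days; a lower number here means a stronger inhibitor, a higher number a weaker inhibitor:

- compound 1 `CN(C)c1cc2[nH]c(C3CCCCC3)nc2cc1NC(=O)c1ccccc1`: > 100 ug/mL
- compound 2 `CCCCOC(=O)Nc1cc2nc(C3CCCCC3)[nH]c2cc1N(CC)CCN(C)C`: > 100 ug/mL
- compound 3 `CCN(CC)c1cc2[nH]c(C3CCCCC3)nc2cc1NC(=O)c1ccc(F)cc1F`: > 100 ug/mL

Compound 1 gives only a limit in this assay, > 100 ug/mL. Compound 2 likewise returns a limit, > 100 ug/mL. Compound 3 also sits at a limit, > 100 ug/mL. For the measured compounds named here, no step between measured compounds can be read here, because the limit of > 100 ug/mL in this assay, at which 3 of the 3 values shown sit: every value is a limit, so compound 1 stands level with the others and no order among them can be stated.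

The untested compound 4 `CN(C)c1cc2[nH]c(C3CCCCC3)nc2cc1NC(=O)c1ccc(OC(F)F)cc1` differs from compound 1 by difluoromethoxy in place of hydrogen on an aromatic carbon.

With every measured value at the limit, no step beyond the scatter is expected for compound 4, and a step that the limit leaves unreadable from compound 1 to compound 4 is set accordingly. Compound 4 is therefore estimated at 150 ug/mL, between 60 ug/mL and 400 ug/mL.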

Compound 4, half-maximal inhibitory concentration: > 100 ug/mL
Compound 4: a limit, no number; the forecaster's own chance of this, stated with the estimate: 80%; the middle value lies beyond the limit too.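

In this assay no step can be read from compound 1 to compound 4, because both values are limits: the limit of > 100 ug/mL in this assay, at which 4 of the 4 values shown sit.

The compounds shown leave open whether difluoromethoxy in place of hydrogen changes cytotoxicity at all, and how any of the four compounds rank beyond that limit.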